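Extending the Polyamine Tail of a Chalcone Amide

A few compounds are considered here, and "the series" means these few. Any claim that something is new, unique, unknown or untested is made for them only; others in the source may bear on it.

Three chalcone polyamine conjugates were tested in a functional assay on PC-3 cells (Homo sapiens) for antiproliferative activity, read by MTT assay, with a stated time of 48 h; a lower number here means a stronger inhibitor, a higher number a weaker inhibitor. Compound 1 `COc1cc(C(=O)/C=C/c2ccc(OCCCC(=O)NCCCCN(CCCN)CCCCN)cc2)cc(OC)c1OC` gives 55400 nM, compound 2 `COc1cc(C(=O)/C=C/c2ccc(OCCCC(=O)NCCCNCCCCNCCN)cc2)cc(OC)c1OC` gives 34000 nM, and compound 3 `COc1cc(C(=O)/C=C/c2ccc(OCCCC(=O)NCCCCNCCCN)cc2)cc(OC)c1OC` gives 79300 nM, the highest number of the three. The step of a 1.4-fold higher number from compound 1 to compound 3 (0.16 log units; within the scatter) stays within the scatter, whereas a 2.3-fold higher number from compound 2 to compound 3 (0.37 log units; beyond the scatter) is modest but beyond it. Compound 4 `COc1cc(C(=O)/C=C/c2ccc(OCCCC(=O)NCCCCN(CCCN)CCCCNCCCN)cc2)cc(OC)c1OC` differs from compound 3 by 4-((3-aminopropyl)amino)butyl in place of hydrogen on an amine nitrogen, lengthening the tail beyond that of either compound 1 or compound 2. Because the step of a 2.3-fold higher number from compound 2 to compound 3 (0.37 log units; beyond the scatter) shows a longer tail with a lower number, a modest fall is expected, a 2.3-fold lower number from compound 3 to compound 4 (0.36 log units; beyond the scatter), for compound 4. Compound 4 is therefore estimated at 35000 nM, within 15000 nM to 80000 nM.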

Compound 4, half-maximal inhibitory concentration: 81600 nM
Compound 4: middle estimate off by 2.3-fold (0.37 log units), on the low side; measured number outside the range, above it.
By their numbers in this assay, from the lowest: compounds 2, 1, 3 and 4 (each within the scatter of the next, the first and the last beyond it).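

In this assay, placing 4-((3-aminopropyl)amino)butyl in place of hydrogen on an amine nitrogen gives a 1.0-fold higher number from compound 3 to compound 4 (0.01 log units; within the scatter) and so leaves the number within the scatter. Setting 3-aminopropyl in place of hydrogen on an amine nitrogen likewise gives a 1.5-fold higher number from compound 1 to compound 4 (0.17 log units; within the scatter) without leaving it, so in this pair of steps the added chain brings no measurable change. Nothing available explains this result. From the compounds shown here alone, whether a carboxylic acid in place of the terminal amine, or a still longer chain on this nitrogen, would shift the number remains open.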